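A few compounds are considered here, and "the series" means these few. Any claim that something is new, unique, unknown or untested is made for them only; others in the source may bear on it.

Measured compounds in a physicochemical assay for solubility, in the presence of a further agent that is not named here; on this read-out lower numbers stand for lower solubility and higher numbers for higher solubility:
- compound 1 `CN(C)CCNc1n[n+]([O-])c2ccccc2[n+]1[O-]` gives 50000000 nM
- compound 2 `CCCN(CCC)CCNc1n[n+]([O-])c2ccccc2[n+]1[O-]` gives > 25000000 nM; this is a limit of the assay, not a number the limit of > 25000000 nM in this assay, at which 1 of the 3 values shown sits.
- compound 3 `CC(C)c1ccc2c(c1)[n+]([O-])c(NCCN(C)C)n[n+]2[O-]` gives 42000000 nM

Compound 3 stands lowest of the two numbers shown in this assay; its nearest neighbour is compound 1, and the step from compound 1 to compound 3 is a 1.2-fold lower number from compound 1 to compound 3 (0.08 log units; within the scatter), which comes with isopropyl in place of hydrogen on an aromatic carbon and lies within the scatter.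

Compound 4 `CCCN(CCC)CCNc1n[n+]([O-])c2ccc(C(C)C)cc2[n+]1[O-]` is not yet measured. It differs from compound 3 in one place: dipropylamino in place of dimethylamino on a saturated chain carbon, two bonds along the chain from a nitrogen on an aromatic ring.

Within the data shown here, the only measured step bearing on this change is the one from compound 1 to compound 2, a step that the limit leaves unreadable from compound 1 to compound 2. Because compound 2 sits at the limit (the limit of > 25000000 nM in this assay, at which 1 of the 3 values shown sits), the size of that step cannot be read, and nothing in the series says whether this change moves the number up, down or not at all beyond the scatter.

With no readable precedent, the expectation for compound 4 in this assay is a step of a 1.1-fold lower number from compound 3 to compound 4 (0.02 log units; within the scatter) from compound 3, with a wide range to reflect that uncertainty. Compound 4 is accordingly estimated at 40000000 nM, between 15000000 nM and 100000000 nM.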

Compound 4, solubility: 39000000 nM
Compound 4: the middle estimate sits 1.0-fold (0.01 log units) above what was measured; low and high end bracket the measured number.
By their numbers in this assay, from the lowest: compounds 4, 3 and 1 (each within the scatter of the next).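

In this assay, the change from dimethylamino to dipropylamino on a saturated chain carbon, two bonds along the chain from a nitrogen on an aromatic ring, now has a readable size on the isopropyl-bearing core: a 1.1-fold lower number from compound 3 to compound 4 (0.03 log units; within the scatter). Among these compounds, with 7 heavy atoms in place of 3 on this chain, compound 3 and compound 4 cannot be told apart in this read-out, which is something the earlier compounds could not show. The value of compound 2 is a limit and not a number, so the steps that reach compound 2 cannot be read, and the same change on the core without isopropyl remains without a size: the limit of > 25000000 nM in this assay, at which 1 of the 4 values shown sits.

The compounds shown leave open whether this insensitivity holds beyond dimethylamino and dipropylamino, for instance with a cyclic amine such as morpholine or piperidine, or with a longer chain on the amine nitrogen. They also leave open whether a carboxylic acid at this place on the chain, or a group other than isopropyl on the aromatic carbon, would give a step beyond the scatter.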